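The source may hold more compounds than are shown below. What is called first, only, known or untested is meant among the compounds shown, and "the series" means these compounds.

Measured in a functional assay on HL-60 cells (Homo sapiens) for antiproliferative activity, with a stated time of 72 h; a higher number here means a weaker inhibitor, a lower number a stronger inhibitor:
compound 1 `OC[C@H]1O[C@@H](n2cnc3c(NCc4ccccc4Br)ncnc32)[C@H](O)[C@@H]1O`: 6600 nM
compound 2 `Cc1ccc(CNc2ncnc3c2ncn3[C@@H]2O[C@H](CO)[C@@H](O)[C@H]2O)cc1`: > 166000 nM (a limit)
compound 3 `COc1cccc(CNc2ncnc3c2ncn3[C@@H]2O[C@H](CO)[C@@H](O)[C@H]2O)c1OC`: > 166000 nM (a limit)

Compound 3 sits at the limit of > 166000 nM in this assay, at which 2 of the 3 values shown sit, so it has a limit and no number. The change to compound 4 `COc1cc(CNc2ncnc3c2ncn3[C@@H]2O[C@H](CO)[C@@H](O)[C@H]2O)cc(OC)c1` is 3,5-dimethoxyphenyl in place of 2,3-dimethoxyphenyl on a saturated chain carbon bound to a nitrogen on an aromatic ring.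

Going by the values given here, two measured steps bear on this, and both are large and beyond the scatter: an at least 25-fold higher number from compound 1 to compound 2 (1.40 log units; beyond the scatter) and an at least 25-fold higher number from compound 1 to compound 3 (1.40 log units; beyond the scatter). Both start from the 2-bromophenyl of compound 1, so neither compares one dimethoxyphenyl with another. The nearest comparison, a step that the two limits leave unreadable from compound 2 to compound 3, cannot be read.

Compound 4 lacks the 2-bromophenyl and keeps a dimethoxyphenyl, so it is expected to resemble compound 3, given an at least 25-fold higher number from compound 1 to compound 3 (1.40 log units; beyond the scatter). No step beyond the scatter is expected, in either direction, and a second limit is the likeliest report. The expected step is a number no higher from compound 3 to compound 4 (the limit leaves the size open). For compound 4 the estimated value is 166000 nM, with an expected range from 50000 nM to 400000 nM.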

Compound 4, half-maximal inhibitory concentration: 20200 nM
For compound 4 the middle estimate is 8.2-fold (0.91 log units) above the measured one, and the stated range ends above it.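

In this assay, the arrangement of the two methoxy groups matters even though the atoms are unchanged: an at least 8.2-fold lower number from compound 3 to compound 4 (0.91 log units; beyond the scatter), so a dimethoxyphenyl at this place is not inactive as such. The 3,5-dimethoxyphenyl also improves on the 4-methylphenyl, with an at least 8.2-fold lower number from compound 2 to compound 4 (0.91 log units; beyond the scatter), but the 2-bromophenyl keeps a modest edge, with a 3.1-fold higher number from compound 1 to compound 4 (0.49 log units; beyond the scatter). The first two steps give only a lower bound on size, since compound 2 and compound 3 each carry a limit and no number: the limit of > 166000 nM in this assay, at which 2 of the 4 values shown sit.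

As far as these compounds go, whether a 3-methoxyphenyl or a 3,5-dichlorophenyl at this place would match the 3,5-dimethoxyphenyl remains open. The step between compound 2 and compound 3 cannot be read, so the 4-methylphenyl and the 2,3-dimethoxyphenyl remain unordered.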